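Methyl on the alkyne: a repeated change on a second core

A few compounds are considered here, and "the series" means these few. Any claim that something is new, unique, unknown or untested is made for them only; others in the source may bear on it.

Measured compounds:
Compound 1 `C#CCNC(=O)c1cccc2c1cc(C)n2-c1nc2c(c(NCc3ccccc3)n1)CCCC2` gives 470 nM in a functional assay on MIA PaCa-2 cells (Homo sapiens) for antiproliferative activity; on this read-out higher numbers stand for an effect only at larger amounts of compound and lower numbers for an effect already at smaller amounts.
Compound 2 `CC#CCNC(=O)c1cccc2c1cc(C)n2-c1nc2c(c(NCc3ccccc3)n1)CCCC2` gives 723 nM in this assay.
Compound 3 `C#CCNC(=O)c1cccc2c1cc(C)n2-c1nc2c(c(NCc3ccccc3)n1)COCC2` gives 1080 nM in this assay.

Compound 2 differs from compound 1 by methyl in place of hydrogen on a triple-bonded carbon, and this change gave a 1.5-fold higher number from compound 1 to compound 2 (0.19 log units; within the scatter). Compound 3 carries a different core; the difference between the two cores is not broken down here. Compound 4 `CC#CCNC(=O)c1cccc2c1cc(C)n2-c1nc2c(c(NCc3ccccc3)n1)COCC2` differs from compound 3 by methyl in place of hydrogen on a triple-bonded carbon, the same change at the same place.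

For the measured compounds named here, for compound 4 the expected step in this assay is a 1.4-fold higher number from compound 3 to compound 4 (0.14 log units; within the scatter), because the only measured example of this change gave a 1.5-fold higher number from compound 1 to compound 2 (0.19 log units; within the scatter) and stayed within the scatter. Compound 4 is therefore expected to give about 1500 nM, with a plausible range from 700 nM to 3500 nM.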

Compound 4, half-maximal effective concentration: 524 nM
For compound 4 the middle estimate is 2.9-fold (0.46 log units) above the measured one; the measured number lies below the stated range.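

In this assay, methyl in place of hydrogen on a triple-bonded carbon gave a 2.1-fold lower number from compound 3 to compound 4 (0.31 log units; beyond the scatter), a modest step. This change therefore does not carry over as a fixed step between these two cores: the same change on two cores in this assay, a 1.5-fold higher number (0.19 log units; within the scatter) from compound 1 to compound 2 and a 2.1-fold lower number (0.31 log units; beyond the scatter) from compound 3 to compound 4, 3.2-fold (0.50 log units) apart, beyond the scatter of two such steps

For the compounds shown here, each core contributes only one pair of compounds, so the result shows that the core can matter for this change, but not why it does or how the change would behave on any other core.

The compounds shown leave open what ethyl or a longer chain on the triple-bonded carbon would do on each core. They also leave open whether a further core would follow compound 2 or compound 4 in its response to the methyl.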